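Ethyl in Place of Fluoro: A Stability Estimate

This account rests on a few compounds, and the source may have more. Where it says the series, first, only, none or still open, it means among the compounds named here.

In an ADME assay (liver) for metabolic stability, with Liver microsome (Rattus norvegicus) as the target, read by LC-MS, using microsomes, with a stated time of 30 min, tested at 4 uM (on this read-out higher numbers stand for a more stable compound and lower numbers for a less stable compound), compound 3 `Cc1nc(N2CCN(C)CC2)c2nc(-c3ccccc3F)n(C3CCOCC3)c2n1` gives 30%. Compound 2 `COc1cccc(-c2nc3c(N4CCN(C)CC4)nc(C)nc3n2C2CCOCC2)c1` gives 30% and compound 1 `COc1ccccc1-c1nc2c(N3CCN(C)CC3)nc(C)nc2n1C1CCOCC1` gives 35%, so all three lie within the scatter of one another. Compound 4 `CCc1ccccc1-c1nc2c(N3CCN(C)CC3)nc(C)nc2n1C1CCOCC1` carries ethyl in place of fluoro on an aromatic carbon, ortho to a large group: ethyl in place of fluoro on an aromatic carbon. Three measured swaps at this aromatic group bear on the change: a number 5 percentage points lower from compound 1 to compound 3 (within the scatter), a number 5 percentage points lower from compound 1 to compound 2 (within the scatter) and no change at the digits printed from compound 2 to compound 3 (within the scatter). None of them involves ethyl, so they point in no firm direction. After steps this small, the expected result is a number 2 percentage points lower from compound 3 to compound 4 (within the scatter), with no shift beyond the scatter anticipated. For compound 4 the estimated value is 28%, with an expected range from 15% to 41%.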

Compound 4, percent of the compound remaining: 51%
For compound 4 the middle estimate is 23 percentage points below the measured one, outside the stated range (above it).
By their numbers in this assay, from the lowest: compounds 2, 3 and 1 (each within the scatter of the next); then compound 4.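

In this assay, ethyl in place of fluoro, ortho to a large group, gives a number 21 percentage points higher from compound 3 to compound 4 (beyond the scatter), and the comparisons with the two methoxy compounds agree: a number 21 percentage points higher from compound 2 to compound 4 (beyond the scatter) and a number 16 percentage points higher from compound 1 to compound 4 (beyond the scatter). For the compounds shown here, the earlier swaps on this aromatic carbon all stayed within the scatter, so compound 4 is the first to show that a change here can move this number beyond it. Nothing available explains the difference. From the compounds shown here alone, whether a shorter methyl or a longer propyl chain would do the same remains open, as does the effect of an amine here.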